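Swapping fluoro for nitro to reach compound 3

This account rests on a few compounds, and the source may have more. Where it says the series, first, only, none or still open, it means among the compounds named here.

Of the compounds shown here, two with a shared core have so far been tested in an ADME assay on cells (Erythrocyte, Homo sapiens), read by hemolysis, with a stated time of 1 h; a higher number here means a weaker inhibitor, a lower number a stronger inhibitor. Compound 1 `CC(=NNC(=S)Nc1ccccc1)c1ccccn1` gives > 10000 nM, which is a limit of the assay and not a number. Compound 2 `CC(=NNC(=S)Nc1ccc(F)cc1)c1ccccn1` gives > 10000 nM, which is also only a limit. Compound 2 therefore has no exact position on the scale, and the evidence so far amounts to the limit of > 10000 nM in this assay, at which 2 of the 2 values shown sit.

Compound 3 `CC(=NNC(=S)Nc1ccc([N+](=O)[O-])cc1)c1ccccn1` carries nitro in place of fluoro on an aromatic carbon of a six-membered aromatic ring of carbon only, para to a large group: nitro in place of fluoro on an aromatic carbon. For the measured compounds named here, the one measured step that bears on this change is a step that the two limits leave unreadable from compound 1 to compound 2, a replacement of hydrogen by fluoro on an aromatic carbon, and it offers no size to carry forward. Resting on the limit of compound 2 at > 10000 nM, no step beyond the scatter is expected in this assay, although a single unreadable step is thin support. The estimated change is a step that the limit leaves unreadable from compound 2 to compound 3. For compound 3 the expected value is 15000 nM, with an estimated range of 8000 nM to 40000 nM.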

Compound 3, half-maximal inhibitory concentration: > 10000 nM
Compound 3 ended at the assay's limit; the forecaster's own chance of this, stated with the estimate: 85%; the middle value does not contradict the limit.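

In this assay compound 3 gives > 10000 nM, which is a limit of the assay and not a number. For the compounds shown here, no step among compound 1, compound 2 and compound 3 can be read. The compounds shown leave open where any of the three stands on the scale, and whether hydrogen, fluoro or nitro on that aromatic carbon makes any difference in this assay.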